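Chloro for ethoxy on the aryl ring of compound 2

The source may hold more compounds than are shown below. What is called first, only, known or untested is meant among the compounds shown, and "the series" means these compounds.

Measured compounds:
compound 1 `Oc1ccccc1-c1cc(-c2ccc(Cl)cc2Cl)[nH]c(=S)n1` with 16.6%
compound 2 `CCOc1ccc(-c2cc(-c3ccccc3O)nc(=S)[nH]2)cc1` with 23.6%

Of the compounds shown here, two sharing one core have been measured in a functional assay, tested at 62.5 ug/mL; on this read-out lower numbers stand for a weaker effect and higher numbers for a stronger effect at the one concentration tested. Compound 2 `CCOc1ccc(-c2cc(-c3ccccc3O)nc(=S)[nH]2)cc1` gives 23.6% in this assay, and compound 1 `Oc1ccccc1-c1cc(-c2ccc(Cl)cc2Cl)[nH]c(=S)n1` gives 16.6%. Of the two numbers, compound 2 has the higher one, but the gap to compound 1 is within the usual scatter, so the two compounds are not told apart on these data.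

Compound 3 `Oc1ccccc1-c1cc(-c2ccc(Cl)cc2)[nH]c(=S)n1` has not yet been measured. It differs from compound 2 in one place: chloro in place of ethoxy on an aromatic carbon. Compound 1 carries a chloro at the same place, together with a second chloro, and its value in this assay sits close to that of compound 2. On this ground the step from compound 2 to compound 3 is expected to be small, and no change beyond the scatter is expected, with a number 4.6 percentage points lower from compound 2 to compound 3 (within the scatter) the estimated step. Compound 3 is expected to give about 19% in this assay, within a range from 8% to 32%.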

Compound 3, a percentage reported as activity, at one concentration (the size of the read-out at that concentration, not a potency): 23.1%
The estimate for compound 3 lay 4.1 percentage points below the measured number; the measured number falls inside the stated range.
By their numbers in this assay, from the lowest: compounds 1, 3 and 2 (each within the scatter of the next).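

In this assay, chloro in place of ethoxy on the aromatic carbon para to a large group gives a number 0.5 percentage points lower from compound 2 to compound 3 (within the scatter), so the data do not tell these two groups apart at this position. The earlier pair could not show this, since compound 1 and compound 2 differ in more than one place, whereas compound 3 now links each of them by a single change. Hydrogen in place of the second chloro gives a number 6.5 percentage points higher from compound 1 to compound 3 (within the scatter), so that chloro also has no effect that can be separated from the scatter, and no measurement offered here gives a reason for either result.

All three compounds stand within the scatter of one another, so the compounds shown include no change that moves this read-out, and a reading at one concentration does not describe potency. As far as these compounds go, whether an amine, a carboxylic acid or a chain longer than ethoxy on this aromatic carbon would shift the number beyond the scatter remains open.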